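The source may hold more compounds than are shown below. What is called first, only, known or untested is meant among the compounds shown, and "the series" means these compounds.

This piece follows a single change in a short series tested in an ADME assay on MDBK cells (Bos taurus) for cytotoxicity, read by MTT assay; on this read-out lower numbers stand for higher toxicity in this test and higher numbers for lower toxicity in this test. For the measured compounds named here, compound 1, `CC1CC(OCCCCCCN2C[C@H](O)[C@@H](O)[C@H](O)[C@H]2CO)CC(C)(C)C1`, is the only member that gives a plain number: in this assay compound 1 gives 250000 nM. Compound 2, `OC[C@@H]1[C@@H](O)[C@H](O)[C@@H](O)CN1CCCCCCOc1cccc(C(F)(F)F)c1`, is a different case: in this assay compound 2 gives > 500000 nM, which is a limit of the test rather than a number. Compound 3, `OC[C@@H]1[C@@H](O)[C@H](O)[C@@H](O)CN1CCCCCCOc1c(F)c(F)c(F)c(F)c1F`, is the same case: in this assay compound 3 gives > 500000 nM, again a limit. So the picture so far is the limit of > 500000 nM in this assay, at which 2 of the 3 values shown sit, and compound 1 is the one compound whose toxicity lands inside the measurable window.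

Compound 4, `COc1ccccc1OCCCCCCN1C[C@H](O)[C@@H](O)[C@H](O)[C@H]1CO`, has not yet been measured. It differs from compound 1 in one place: 2-methoxyphenyl in place of 3,3,5-trimethylcyclohexyl on an oxygen on a saturated carbon. Going by the values given here, no step between two measured compounds exists to lean on, so the expectation rests on the spread of the values alone. The step of a 1.6-fold higher number from compound 1 to compound 4 (0.20 log units; within the scatter) is expected to be small to moderate, toward lower toxicity, because the limit of > 500000 nM in this assay, at which 2 of the 3 values shown sit, shows where most of the series sits. Compound 4 is therefore estimated at 400000 nM, within 150000 nM to 800000 nM, with a fair chance that the test again reports only a limit.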

Compound 4, half-maximal cytotoxic concentration: > 500000 nM
Compound 4 gave a limit, no number; the forecaster's own chance of this, stated with the estimate: 55%; middle value at least 1.2-fold (0.09 log units) away from the limit.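

In this assay, replacing 3,3,5-trimethylcyclohexyl with 2-methoxyphenyl on this oxygen gives an at least 2.0-fold higher number from compound 1 to compound 4 (0.30 log units; that floor lies within the scatter). For the compounds shown here, this is the first one-place step, and it can only be read as a floor: the true size of the step stays unknown, and that floor does not go beyond the scatter. So this exchange of a non-aromatic carbon ring for an aromatic ring carrying an added oxygen shows no sign of a drop in the number, and compound 1 remains the only compound with a plain value, while the others gather at one ceiling: the limit of > 500000 nM in this assay, at which 3 of the 4 values shown sit.

The compounds shown leave open how far compound 4 really lies from compound 1, and whether the change of ring or the methoxy group matters more in this assay. A plain phenyl or a plain cyclohexyl on this oxygen would separate those two parts of the change, while an amine or a carboxylic acid at the same place would test a quite different kind of group.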